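A hydroxyl for a methyl on the amino acid arm

A few compounds are considered here, and "the series" means these few. Any claim that something is new, unique, unknown or untested is made for them only; others in the source may bear on it.

Compound 1 `C=C1[C@H](C)CCC[C@]1(C)CC/C(C)=C/CC1=C(O)C(=O)C=C(N[C@@H](C(=O)O)C(C)C)C1=O` stands lowest of the two numbers in an ADME assay on L1210 cells (Mus musculus) for cytotoxicity, with a stated time of 48 h (on this read-out lower numbers stand for stronger inhibition and higher numbers for weaker inhibition), giving 3.4 ug/mL. Compound 2 `CC1=CCC[C@H]2[C@](C)(CC3=C(O)C(=O)C=C(N[C@@H](CO)C(=O)O)C3=O)[C@@H](C)CC[C@]12C` sits within the scatter of it, at 3.8 ug/mL in this assay. Compound 3 `CC1=CCC[C@](C)(CC/C(C)=C/CC2=C(O)C(=O)C=C(N[C@H](C(=O)O)[C@H](C)O)C2=O)[C@@H]1C` gives no number in this assay but only a limit, > 10 ug/mL; this is the limit of > 10 ug/mL in this assay, at which 1 of the 3 values shown sits.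

Compound 4 `C=C1[C@H](C)CCC[C@]1(C)CC/C(C)=C/CC1=C(O)C(=O)C=C(N[C@H](C(=O)O)[C@@H](C)O)C1=O` differs from compound 1 in one place: 1-carboxy-2-hydroxypropyl in place of 1-carboxy-2-methylpropyl on an amine nitrogen. For the measured compounds named here, no measured pair shows this change on a shared core. Compound 3 also carries 1-carboxy-2-hydroxypropyl and in this assay reaches only the limit > 10 ug/mL. Compound 4 is expected to give 6 ug/mL in this assay, between 2.5 ug/mL and 14 ug/mL. The expected step of a 1.8-fold higher number from compound 1 to compound 4 (0.25 log units; within the scatter) would be a modest weakening, near the edge of the scatter.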

Compound 4, half-maximal inhibitory concentration: > 10 ug/mL
Compound 4: a limit, no number (the forecaster's own chance of this, stated with the estimate: 30%); middle value at least 1.6-fold (0.22 log units) away from the limit.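

In this assay, for the compounds shown here, 1-carboxy-2-hydroxypropyl in place of 1-carboxy-2-methylpropyl on the amine nitrogen gives an at least 2.9-fold higher number from compound 1 to compound 4 (0.46 log units; beyond the scatter), the first step at this position read on a shared core. The two compounds carrying 1-carboxy-2-hydroxypropyl, compound 3 and compound 4, are both limits, not numbers: the limit of > 10 ug/mL in this assay, at which 2 of the 4 values shown sit.

Compound 2, on another core with a hydroxyl on its amino acid arm, goes against any general hydroxyl pattern, with 3.8 ug/mL. Going by these compounds, the full size of the step stays open, as does how a methoxy group or an amine would read in place of that hydroxyl.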